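A few compounds are considered here, and "the series" means these few. Any claim that something is new, unique, unknown or untested is made for them only; others in the source may bear on it.

- compound 1 `O=C(NC(=S)Nc1ccc(Sc2ncccn2)cc1)c1ccccc1`: "not determined" (no result reported)
- compound 2 `O=C(NC(=O)c1ccccc1)Nc1ccc(Sc2ncc(Br)cn2)cc1`: 2000 nM

In a functional assay on Panc430 cells (Homo sapiens) for cytotoxicity, read by MTT assay (on this read-out higher numbers stand for weaker inhibition and lower numbers for stronger inhibition), compound 1 stands at "not determined" (no result reported), so it offers no number to start from. The structural change leads to compound 3 `O=C(NC(=S)Nc1ccc(Sc2ncc(Br)cn2)cc1)c1ccccc1`: bromo in place of hydrogen on an aromatic carbon, with pyrimidin-2-yl becoming 5-bromopyrimidin-2-yl. Nothing measured shows a direction for this step in this assay, so none beyond the usual scatter is expected. For the measured compounds named here, the only measured number is that of compound 2, at 2000 nM, and it anchors the expectation. For compound 3, the estimated value is 1500 nM, with an expected range of 300 nM to 8000 nM.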

Compound 3, half-maximal inhibitory concentration: 7500 nM
Compound 3: the middle estimate sits 5.0-fold (0.70 log units) below what was measured; the measured number falls inside the stated range.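

For the compounds shown here, with compound 1 at "not determined" (no result reported) in this assay, no step from it to compound 3 can be read. The compounds shown leave open what bromo in place of hydrogen does to the read-out in this assay. No evidence shown bears on this result.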